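The source may hold more compounds than are shown below. What is called first, only, known or untested is meant among the compounds shown, and "the series" means these compounds.

Measured compounds:
Compound 1 `COc1ccc(/C=C2\Cc3c(cc(OC)c(OC)c3OC)C2=O)cc1` gives 429 nM in a functional assay on MDA-MB-231 cells (Homo sapiens) for antiproliferative activity, read by MTT assay, with a stated time of 48 h; a lower number here means a stronger inhibitor of growth, a higher number a weaker inhibitor of growth.
Compound 2 `COc1ccc(/C=C2\Cc3c(cc(OC)c(OC)c3OC)C2=O)cc1F` gives 521 nM in this assay.
Compound 3 `COc1ccc(/C=C2\CCc3c(cc(OC)c(OC)c3OC)C2=O)cc1` gives 38700 nM in this assay.

Compound 1 and compound 2 share a core and differ in one place: fluoro in place of hydrogen on an aromatic carbon. The step of a 1.2-fold higher number from compound 1 to compound 2 (0.08 log units; within the scatter), so the two values cannot be told apart by this measurement. Compound 3 carries a different core, and the difference between the two cores is not broken down here; what the values show is that compound 3 sits far above both compound 1 and compound 2 in this assay.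

Compound 4 `COc1ccc(/C=C2\CCc3c(cc(OC)c(OC)c3OC)C2=O)cc1F` has not yet been measured. It stands to compound 3 as compound 2 stands to compound 1: fluoro in place of hydrogen on an aromatic carbon. The place of the change reads the same in both pairs, so it is the same change made on the second core. Going by the values given here, the only guide to its size is the earlier pair, where the step was within the scatter, and the expectation is that the step is of the same order because a 1.2-fold higher number from compound 1 to compound 2 (0.08 log units; within the scatter). Compound 4 is therefore expected to give a number close to that of compound 3, with the step estimated as a 1.2-fold higher number from compound 3 to compound 4 (0.07 log units; within the scatter). The estimate for compound 4 in this assay is 45000 nM, expected to fall between 18000 nM and 110000 nM.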

Compound 4, concentration for 50% growth inhibition: 29400 nM
Estimate against measurement, compound 4: 1.5-fold (0.18 log units) above; measured number inside the range.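

In this assay, fluoro in place of hydrogen on the second core, the change from 4-methoxyphenyl to 3-fluoro-4-methoxyphenyl, gives a 1.3-fold lower number from compound 3 to compound 4 (0.12 log units; within the scatter), so the two values cannot be told apart by this measurement. Set beside the same change on the first core, the new step does not differ from the earlier one: the same change on two cores in this assay, a 1.2-fold higher number (0.08 log units; within the scatter) from compound 1 to compound 2 and a 1.3-fold lower number (0.12 log units; within the scatter) from compound 3 to compound 4, 1.6-fold (0.20 log units) apart, within the scatter of two such steps. This shows that, across these two pairs, the change carries from one core to the other with no measurable effect on the number, even though the two cores give values far apart; it does not show that fluoro has no effect at all, since a small real step could lie hidden within the scatter, and two pairs cannot establish a rule for the whole series or for other assays.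

The compounds shown leave open whether a larger or different group on that same aromatic carbon, such as chloro, a hydroxyl group, an amine or a carboxylic acid, would also carry from one core to the other without a readable step. They also leave open whether replacing the methoxy group with a longer alkoxy chain would give steps of the same size on both cores.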